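Inverting One Ring Stereocentre of Compound 2

The source may report more compounds than this note shows. Statements on the series, on what has been measured and on what is new or still open speak of the compounds shown alone.

Compound 1 `O=c1ccn([C@H]2C[C@H](O)[C@@H](CO)S2)c(=O)[nH]1` and compound 2 `Cc1cn([C@H]2C[C@H](O)[C@@H](CO)S2)c(=O)[nH]c1=O` share one core. In a functional assay on HEp-2 cells (Homo sapiens) for inhibition (a lower number here means a stronger inhibitor, a higher number a weaker inhibitor), compound 1 gives 2100 nM, while compound 2 gives 140 nM, the lower of the two numbers; the step of a 15-fold lower number from compound 1 to compound 2 (1.18 log units; beyond the scatter) is large. Compound 3 `Cc1cn([C@@H]2C[C@H](O)[C@@H](CO)S2)c(=O)[nH]c1=O` differs from compound 2 in this way: the two compounds have the same atoms and bonds and differ only in configuration as drawn: 1 of 3 stereo elements differ; a stereocentre at a saturated ring carbon is drawn R in compound 2 and S in compound 3. Among the measured compounds shown here, no measured step alters a configuration, so the single step seen, a methyl for a hydrogen, does not bear on this change. Compound 3 is expected to be weaker in this assay, an estimated step of a 14-fold higher number from compound 2 to compound 3 (1.15 log units; beyond the scatter). Compound 3 is estimated at 2000 nM, within 400 nM to 20000 nM.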

Compound 3, half-maximal inhibitory concentration: 25000 nM
Estimate against measurement, compound 3: 13-fold (1.10 log units) below; the measured number lies above the stated range.
By their numbers in this assay, from the lowest: compound 2; then compound 1; then compound 3.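

In this assay, this ring stereocentre proves decisive: redrawing it from R to S gives a 180-fold higher number from compound 2 to compound 3 (2.25 log units; beyond the scatter). The earlier compounds shown here showed only the effect of a methyl in place of hydrogen on an aromatic carbon, whereas here no atom or bond changes. The loss can be traced to this stereocentre alone, because nothing else separates the pair: the fact that compounds 2 and 3 differ only in the configuration as drawn

The compounds shown leave open whether the same inversion costs as much in compound 1, which carries hydrogen in place of the methyl. They also leave open how an ethyl group or a bromine atom at that aromatic carbon would read in either configuration.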